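Urea anilide swap: dichlorophenyl for methoxyphenyl

The source may report more compounds than this note shows. Statements on the series, on what has been measured and on what is new or still open speak of the compounds shown alone.

Compound 1, `COc1ccccc1NC(=O)N[C@@H]1C2CCN(CC2)[C@@H]1Cc1cccnc1`; in an assay on a protein complex for binding affinity to Neuronal acetylcholine receptor; alpha4/beta2 (Homo sapiens) (on this read-out higher numbers stand for weaker inhibition and lower numbers for stronger inhibition), compound 1 gives > 10000 nM, a limit of the assay.
Compound 2, `COc1cccc(NC(=O)N[C@@H]2C3CCN(CC3)[C@@H]2Cc2cccnc2)c1`; in this assay compound 2 gives > 10000 nM, likewise a limit.

Compound 2 therefore stands at the limit of this assay, and no number places it relative to compound 1. Within the data shown here, the one measured step, a step that the two limits leave unreadable from compound 1 to compound 2, cannot be read, since both ends are limits; this is all that the limit of > 10000 nM in this assay, at which 2 of the 2 values shown sit, records.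

Compound 3, `O=C(Nc1ccc(Cl)c(Cl)c1)N[C@@H]1C2CCN(CC2)[C@@H]1Cc1cccnc1`, has not been measured in this assay. Its change from compound 2 is 3,4-dichlorophenyl in place of 3-methoxyphenyl on an amide-type nitrogen. Among the measured compounds shown here, no measured step bears on this change: the only step between measured compounds concerns the position of the methoxy group on the phenyl ring, and even that step is unreadable. The expectation for compound 3 can rest only on the fact that compound 2 sits at the limit, so compound 3 is expected to stay near that limit, with the step that the limit leaves unreadable from compound 2 to compound 3 estimated as no change beyond the scatter. Compound 3 is estimated at 15000 nM, within 3000 nM to 80000 nM.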

Compound 3, inhibition constant: > 10000 nM
Compound 3 gave a limit, no number (the forecaster's own chance of this, stated with the estimate: 70%); the middle value does not contradict the limit.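

In this assay compound 3 gives > 10000 nM, which is a limit of the assay. No step among compound 1, compound 2 and compound 3 can be read: the limit of > 10000 nM in this assay, at which 3 of the 3 values shown sit.

The compounds shown leave open which group on the amide-type nitrogen, if any, would give a number rather than a limit in this assay.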